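The source may report more compounds than this note shows. Statements on the series, on what has been measured and on what is new or still open speak of the compounds shown alone.

The series shares the core of compound 1 `COc1cccc(C(=O)NN(C(=O)c2cc(C)cc(C)c2)C(C)(C)C)c1` and varies the group on one carbonyl carbon. In an assay on cells for agonist activity at ecdysone receptor (Bombyx mori), read by a luciferase reporter, with a stated time of 24 h (on this read-out higher numbers stand for an effect only at larger amounts of compound and lower numbers for an effect already at smaller amounts), compound 1 gives 66.1 nM. Compound 2 `CCCCC(=O)NN(C(=O)c1cc(C)cc(C)c1)C(C)(C)C` carries butyl at that carbonyl carbon and in this assay gives 1860 nM; compound 3 `CCCCCCCC(=O)NN(C(=O)c1cc(C)cc(C)c1)C(C)(C)C` carries heptyl and in this assay gives 97.7 nM. Among the three numbers compound 3 sits second highest: its nearest neighbour is compound 1, separated by a 1.5-fold higher number from compound 1 to compound 3 (0.17 log units; within the scatter), a gap within the scatter, so no order between these two can be read; its furthest neighbour is compound 2, with a 19-fold lower number from compound 2 to compound 3 (1.28 log units; beyond the scatter). The step of a 28-fold higher number from compound 1 to compound 2 (1.45 log units; beyond the scatter) shows the same spread from the other side.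

Compound 4 `CCCCCCCCCC(=O)NN(C(=O)c1cc(C)cc(C)c1)C(C)(C)C` is next: ethyl in place of hydrogen on a saturated chain carbon, seven bonds along the chain from a carbonyl carbon, so the chain of compound 3 is lengthened further. Among the compounds with values here, only one measured step bears on chain length at this position, a 19-fold lower number from compound 2 to compound 3 (1.28 log units; beyond the scatter), and it was large; no measured pair covers a chain longer than heptyl, so whether the lowering continues, levels off or reverses is unsupported. Given a 19-fold lower number from compound 2 to compound 3 (1.28 log units; beyond the scatter), a further but smaller lowering, or a result within the scatter, is expected in this assay for compound 4, as a 1.6-fold lower number from compound 3 to compound 4 (0.21 log units; within the scatter). The estimate for compound 4 in this assay is 60 nM, with a range from 20 nM to 250 nM.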

Compound 4, half-maximal effective concentration: 1550 nM
The estimate for compound 4 lay 26-fold (1.41 log units) below the measured number; the whole stated range lies below it.
By their numbers in this assay, from the lowest: compounds 1 and 3 (each within the scatter of the next); then compounds 4 and 2 (each within the scatter of the next).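

In this assay, the gain seen on going from butyl to heptyl does not continue: ethyl in place of hydrogen, seven bonds along the chain from a carbonyl carbon, gives a 16-fold higher number from compound 3 to compound 4 (1.20 log units; beyond the scatter) and so the response to chain length at this carbonyl carbon runs in both directions across the three chains shown. The nonyl chain of compound 4 and the butyl chain of compound 2 cannot be told apart, with a 1.2-fold lower number from compound 2 to compound 4 (0.08 log units; within the scatter) and so no order can be read between them, even though the two chains lie on either side of heptyl. Set against the 3-methoxyphenyl group, nonyl gives a 23-fold higher number from compound 1 to compound 4 (1.37 log units; beyond the scatter) and so, of the three chains shown, only the heptyl of compound 3 stays within the scatter of compound 1.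

Going by these compounds, with only butyl, heptyl and nonyl in hand, it stays open how pentyl, hexyl or octyl would fall, where along the chain the turn lies, and whether a branched chain or a chain ending in an amine or a carboxylic acid would follow the same course. Nothing available accounts for the turn at nonyl.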